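The compounds below may be only part of what the source reports. "The series", "measured", "known", "first", "only" and "open" are said of these compounds alone.

Measured so far:
compound 1 `Cc1ccc(N2CCN(c3ccc(C(=O)/C=C/c4ccccc4)cc3)CC2)c(C)c1` — 15%
compound 2 `Cc1ccc(S(=O)(=O)N2CCN(c3ccc(C(=O)/C=C/c4ccccc4)cc3)CC2)cc1` — 30.8%
compound 3 `O=C(/C=C/c1ccccc1)c1ccc(N2CCN(S(=O)(=O)c3ccc4ccccc4c3)CC2)cc1` — 35%

In a functional assay on the whole organism (strain Kunming) for inhibition, with Mus musculus as the target, with a stated time of 1 h, at a dose of 40 mg/kg by the oral route (on this read-out lower numbers stand for less inhibition and higher numbers for more inhibition at the one dose given (going by the name of the read-out)), compound 3 gives the highest of the three numbers, though the gap to compound 2 stays within the scatter, while the gap to compound 1 lies beyond it. Compound 4 `COc1ccc(S(=O)(=O)N2CCN(c3ccc(C(=O)/C=C/c4ccccc4)cc3)CC2)cc1` differs from compound 3 by 4-methoxyphenyl in place of naphthalen-2-yl on a sulfonyl sulfur. The step that bears on this change is a number 4.2 percentage points higher from compound 2 to compound 3 (within the scatter), which stayed within the scatter; the step of a number 15.8 percentage points higher from compound 1 to compound 2 (beyond the scatter) concerns a different site. A swap of one aryl group for another on the sulfonyl sulfur is therefore expected to move this assay little or not at all beyond the scatter, and compound 4 is estimated at 30%, between 18% and 42%, an expected step of a number 5 percentage points lower from compound 3 to compound 4 (within the scatter).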

Compound 4, a percentage reported as inhibition, in the whole organism at one dose (the size of the read-out at that dose, not a potency): 45.2%
Beside the measured number, compound 4's estimate is 15.2 percentage points below it; the whole stated range lies below it.
By their numbers in this assay, from the lowest: compound 1; then compounds 2 and 3 (each within the scatter of the next); then compound 4.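

In this assay the choice of aryl group on the sulfonyl sulfur proves to matter, since a number 10.2 percentage points higher from compound 3 to compound 4 (beyond the scatter) and a number 14.4 percentage points higher from compound 2 to compound 4 (beyond the scatter) both pass the scatter, which the swap of 4-methylphenyl for naphthalen-2-yl had not done. The small change of methyl to methoxy on an aromatic carbon therefore shifts the number, and the full replacement of 2,4-dimethylphenyl on the amine nitrogen in a ring gives a number 30.2 percentage points higher from compound 1 to compound 4 (beyond the scatter). Nothing measured here explains these differences. Going by these compounds, whether an ethoxy group, a hydroxyl or an amine on that aromatic carbon would match methoxy remains open.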